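Pyridin-3-yl in place of 1,3-thiazol-2-yl in compound 3

The source may report more compounds than this note shows. Statements on the series, on what has been measured and on what is new or still open speak of the compounds shown alone.

Measured so far in a functional assay on MCF7 cells (Homo sapiens) for inhibition, with a stated time of 96 h (on this read-out higher numbers stand for weaker inhibition and lower numbers for stronger inhibition), for three compounds:
Compound 1 `COc1cc(C(=O)c2cn(-c3cccc(C)c3)cc2-c2nccs2)cc(OC)c1OC` gives 20 nM
Compound 2 `COc1cc(C(=O)c2cn(-c3ccc(C)cc3)cc2-c2nccs2)cc(OC)c1OC` gives 14 nM
Compound 3 `COc1cc(C(=O)c2cn(-c3ccc(F)cc3)cc2-c2nccs2)cc(OC)c1OC` gives 22 nM

Compound 3 stands level with the other two within the scatter, and a 1.1-fold higher number from compound 1 to compound 3 (0.04 log units; within the scatter) and a 1.6-fold higher number from compound 2 to compound 3 (0.20 log units; within the scatter) are the steps that reach it. Compound 4 `COc1cc(C(=O)c2cn(-c3ccc(F)cc3)cc2-c2cccnc2)cc(OC)c1OC` keeps the 4-fluorophenyl group of compound 3 but carries pyridin-3-yl in place of 1,3-thiazol-2-yl on an aromatic carbon of a five-membered aromatic ring with 1 nitrogen.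

For the measured compounds named here, no measured step touches this place. The measured steps all concern the group on the aromatic nitrogen, namely a 1.4-fold lower number from compound 1 to compound 2 (0.15 log units; within the scatter) as well as the two already given, and all lie within the scatter. All three measured compounds carry 1,3-thiazol-2-yl, so the data hold no comparison for this change and give no direction for it. In this assay no step beyond the scatter is expected, though with wide uncertainty. This expectation starts from compound 3 at 22 nM as its anchor. The estimate amounts to a 1.4-fold higher number from compound 3 to compound 4 (0.13 log units; within the scatter) as an expected step, and its direction is not firm. The estimated value for compound 4 is 30 nM with an expected range from 8 nM to 110 nM in this estimate.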

Compound 4, half-maximal inhibitory concentration: 39 nM
For compound 4 the middle estimate is 1.3-fold (0.11 log units) below the measured one; the range from low to high includes it.
By their numbers in this assay, from the lowest: compounds 2, 1, 3 and 4 (each within the scatter of the next, the first and the last beyond it).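

Compound 4 is the only compound shown without 1,3-thiazol-2-yl on this aromatic carbon, and in this assay the exchange for pyridin-3-yl gives a 1.8-fold higher number from compound 3 to compound 4 (0.25 log units; within the scatter). This place therefore accepts a six-membered aromatic ring with 1 hetero atom as well as a five-membered aromatic ring with 2 hetero atoms, and a ring sulfur is not needed for compound 4 to reach 39 nM in this read-out. Nothing at hand explains why the two groups read alike.

The compounds shown leave open how a plain phenyl, a pyridin-4-yl or a furan-2-yl would read at this place, and whether a group without an aromatic ring, such as a morpholine or a carboxylic acid, would be accepted there at all. Pyridin-3-yl appears here only together with the 4-fluorophenyl group, and it remains open whether the same level reading would hold with 3-methylphenyl or 4-methylphenyl on the ring nitrogen.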